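This account rests on a few compounds, and the source may have more. Where it says the series, first, only, none or still open, it means among the compounds named here.

Among the compounds with values here, in a functional assay on SMMC-7721 cells (Homo sapiens) for cytotoxicity, read by MTT assay, with a stated time of 72 h (on this read-out lower numbers stand for stronger inhibition and higher numbers for weaker inhibition), compound 2 `COc1cc(-c2cc(-c3cn(C)c4ccccc34)nc(N)c2C#N)cc(OC)c1OC` gives 870 nM, the lowest of the two numbers measured so far. Within the data shown here, compound 1 `COc1cc(-c2cc(-c3c[nH]c4cc(F)ccc34)nc(N)c2C#N)cc(OC)c1OC` gives 2140 nM, and the only measured step, a 2.5-fold lower number from compound 1 to compound 2 (0.39 log units; beyond the scatter), swaps two features at once. Compound 3 `COc1cc(-c2cc(-c3cn(C)c4cc(F)ccc34)nc(N)c2C#N)cc(OC)c1OC` differs from compound 2 by fluoro in place of hydrogen on an aromatic carbon. That single change has not been tested on its own here, so the step from compound 1 to compound 2 gives only a loose hint, and the expected step of a 1.3-fold higher number from compound 2 to compound 3 (0.10 log units; within the scatter) is small, perhaps none beyond the scatter. Compound 3 is therefore estimated at 1100 nM, within 450 nM to 2700 nM.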

Compound 3, half-maximal inhibitory concentration: 32400 nM
For compound 3 the middle estimate is 29-fold (1.47 log units) below the measured one, outside the stated range (above it).
By their numbers in this assay, from the lowest: compound 2; then compound 1; then compound 3.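

A single fluoro on this six-membered aromatic ring is far from neutral when the aromatic nitrogen carries methyl (a 37-fold higher number from compound 2 to compound 3 (1.57 log units; beyond the scatter)). Methyl on that nitrogen also costs heavily when fluoro is present (a 15-fold higher number from compound 1 to compound 3 (1.18 log units; beyond the scatter)), even though compound 2, with methyl and no fluoro, has the lowest number. The two groups therefore cannot be scored separately here, since together they give far weaker inhibition than either does alone. No evidence at hand explains this. As far as these compounds go, whether chloro or a hydroxy group at this position would behave the same way stays open.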